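Diacylhydrazine series: changing the aryl on one carbonyl

The compounds below may be only part of what the source reports. "The series", "measured", "known", "first", "only" and "open" are said of these compounds alone.

Compound 1 `CC(C)(C)N(NC(=O)c1cccc(C#N)c1)C(=O)c1ccccc1Cl`: 955 nM
Compound 2 `CC(C)(C)N(NC(=O)c1ccc(Cl)cc1)C(=O)c1ccccc1Cl`: 115 nM

Compound 2 gives the lowest number of the two in an assay on cells for agonist activity at ecdysone receptor (Bombyx mori), read by a luciferase reporter, with a stated time of 24 h; a lower number here means that less compound is needed, a higher number that more compound is needed for the effect; the gap between them is an 8.3-fold lower number from compound 1 to compound 2 (0.92 log units; beyond the scatter). Compound 3 `Cc1ccc(C(=O)NN(C(=O)c2ccccc2Cl)C(C)(C)C)cc1C` differs from compound 2 as follows: 3,4-dimethylphenyl in place of 4-chlorophenyl on a carbonyl carbon. Within the data shown here, no measured step covers this change; the step from compound 1 to compound 2 shows only that the group on this carbonyl carbon moves the value, with an 8.3-fold lower number from compound 1 to compound 2 (0.92 log units; beyond the scatter). Among the measured compounds shown here, with no closer precedent, a modest shift at most is expected. Compound 3 is therefore estimated at 80 nM, range 25 nM to 300 nM, which is expected to mean a 1.4-fold lower number from compound 2 to compound 3 (0.16 log units; within the scatter).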

Compound 3, half-maximal effective concentration: 87.1 nM
Beside the measured number, compound 3's estimate is 1.1-fold (0.04 log units) below it, within the range that was stated.
By their numbers in this assay, from the lowest: compounds 3 and 2 (each within the scatter of the next); then compound 1.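

In this assay, 3,4-dimethylphenyl and 4-chlorophenyl on this carbonyl carbon cannot be separated (a 1.3-fold lower number from compound 2 to compound 3 (0.12 log units; within the scatter)), so a group without chlorine, and with no nitrile, sits at the level of compound 2. Compound 1 stays apart from this pair, with 3-cyanophenyl replaced by 3,4-dimethylphenyl giving an 11-fold lower number from compound 1 to compound 3 (1.04 log units; beyond the scatter) on top of the step already seen with 4-chlorophenyl. No measurement at hand explains either step.

Open, going by these compounds, is whether an amine or a carboxylic acid on this phenyl ring keeps the level of compound 2 and compound 3. Also open, on these data alone, is whether the other carbonyl's aryl group or the tert-butyl group moves the value as much.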